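Replacing hydroxycarbamoyl with 6-(methylcarbamoyl)hexyl on the shared core

A few compounds are considered here, and "the series" means these few. Any claim that something is new, unique, unknown or untested is made for them only; others in the source may bear on it.

Measured in a functional assay on CNE-2 cells (Homo sapiens) for inhibition, read by MTT assay, with a stated time of 72 h; a higher number here means a weaker inhibitor, a lower number a stronger inhibitor:
compound 1 `Nc1nc2cc(-c3nn(CCCC(=O)NO)c4ncnc(N)c34)ccc2o1`: > 50000 nM
compound 2 `Nc1nc2cc(-c3nn(CC(=O)NO)c4ncnc(N)c34)ccc2o1`: 12200 nM

The entry for compound 1 is a limit, not a number. Going by the values given here, compound 2 therefore holds the only actual number so far, and it has no second number to be ranked against.

Compound 3 `CNC(=O)CCCCCCCn1nc(-c2ccc3oc(N)nc3c2)c2c(N)ncnc21` is still unmeasured. The change is 6-(methylcarbamoyl)hexyl in place of hydroxycarbamoyl on a saturated chain carbon bound to an aromatic nitrogen.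

Among the compounds with values here, one measured step bears on this place: an at least 4.0-fold lower number from compound 1 to compound 2 (0.61 log units; beyond the scatter). Hydroxycarbamoyl is present on both sides of that step, so no measured compound shows what its loss does, and the guide is a weak one. Going by an at least 4.0-fold lower number from compound 1 to compound 2 (0.61 log units; beyond the scatter), where the smaller group gave the lower number, a higher number is expected for compound 3 in this assay. The expected change is a 2.0-fold higher number from compound 2 to compound 3 (0.31 log units; beyond the scatter). For compound 3 the estimate is 25000 nM, with an expected range of 6000 nM to 80000 nM.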

Compound 3, half-maximal inhibitory concentration: 2250 nM
Compound 3: middle estimate off by 11-fold (1.05 log units), on the high side; measured number below the stated range.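

In this assay, hydroxycarbamoyl is not needed for activity on a saturated chain carbon bound to an aromatic nitrogen: 6-(methylcarbamoyl)hexyl in its place gives a 5.4-fold lower number from compound 2 to compound 3 (0.73 log units; beyond the scatter). Going by these compounds alone, the only earlier step, an at least 4.0-fold lower number from compound 1 to compound 2 (0.61 log units; beyond the scatter), had the smaller group on the lower side, so group size alone does not order the series, and compound 3 goes against that earlier trend, with the largest group of the three and the lowest number in this assay. Measured against the compound with the shorter hydroxycarbamoyl-bearing chain, the change gives an at least 22-fold lower number from compound 1 to compound 3 (1.34 log units; beyond the scatter), but this step stays open-ended because compound 1 is recorded as a limit, not a number: the limit of > 50000 nM in this assay, at which 1 of the 3 values shown sits.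

The compounds shown do not separate the effect of chain length from that of the end group: the long chain appears only with the methylcarbamoyl end. Hydroxycarbamoyl on that same long chain, or a carboxylic acid or primary amide at its end, would show which of the two accounts for the lower number.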